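Methylating a phenol in a weak series of amide inhibitors

A few compounds are considered here, and "the series" means these few. Any claim that something is new, unique, unknown or untested is made for them only; others in the source may bear on it.

Of the compounds shown here, three have been measured in an assay for inhibition of HSP60/HSP10 (Homo sapiens), with a stated time of 60 min; a higher number here means a weaker inhibitor, a lower number a stronger inhibitor. Compound 2 `O=C(Nc1ccccc1)c1cc(Br)cc(Br)c1O` carries a free hydroxy on its core, and in this assay compound 2 gives 63000 nM. Compound 1 `COc1c(Br)cc(Br)cc1C(=O)Nc1ccccc1` differs from it by methyl in place of hydrogen on an oxygen on an aromatic ring. For compound 1 this assay reports only a limit, > 100000 nM, not a number. The step is therefore an at least 1.5-fold higher number from compound 2 to compound 1 (0.20 log units; that floor lies within the scatter), and its floor follows from the limit of > 100000 nM in this assay, at which 2 of the 3 values shown sit.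

Compound 3 `O=C(Nc1cccc(Cl)c1)c1cc(Br)ccc1O` rests on a different core; how its core differs from that of compound 2 is not broken down here. For compound 3 this assay again gives only a limit, > 100000 nM, and no number.

Compound 4 `COc1ccc(Br)cc1C(=O)Nc1cccc(Cl)c1` is not yet measured. It differs from compound 3 by methyl in place of hydrogen on an oxygen on an aromatic ring, the same change as that made from compound 2 to compound 1, at a place described in the same words. Since compound 3 already sits at the limit with > 100000 nM, and the same change earlier gave an at least 1.5-fold higher number from compound 2 to compound 1 (0.20 log units; that floor lies within the scatter), compound 4 is expected to sit at or beyond that limit as well, with an estimated step that the limit leaves unreadable from compound 3 to compound 4. The estimate for compound 4 is 250000 nM, expected to lie between 90000 nM and 1000000 nM, and most likely this assay will report only a limit for compound 4.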

Compound 4, half-maximal inhibitory concentration: > 100000 nM
Compound 4 ended at the assay's limit (the forecaster's own chance of this, stated with the estimate: 90%); the middle value lies beyond the limit too.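

In this assay, the step from hydroxy to methoxy between compound 3 and compound 4 cannot be read, since both compounds end at a limit of the assay rather than at a number: the limit of > 100000 nM in this assay, at which 3 of the 4 values shown sit.

The compounds shown leave open how far past that limit compound 3 and compound 4 truly lie, and whether the change from hydroxy to methoxy makes any real difference on either core.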